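This account rests on a few compounds, and the source may have more. Where it says the series, first, only, none or still open, it means among the compounds named here.

Compound 1 `Cc1cc2ccccc2nc1-c1cn(CCC(F)(F)C(F)(F)C(F)(F)C(F)(F)C(F)(F)C(F)(F)C(F)(F)C(F)(F)F)nn1` was examined in a functional assay on THP-1 cells (Homo sapiens) for cytotoxicity, read by MTT assay, with a stated time of 24 h; on this read-out lower numbers stand for stronger inhibition and higher numbers for weaker inhibition. In this assay compound 1 gives > 100 ug/mL, which is a limit of the assay and not a number. Compound 1 thus rests at the limit of > 100 ug/mL in this assay, at which 2 of the 3 values shown sit, so its place within the set cannot be fixed more closely than that. Compound 4 `CCCCc1cc2ccccc2nc1-c1cn(CCC(F)(F)C(F)(F)C(F)(F)C(F)(F)C(F)(F)C(F)(F)C(F)(F)C(F)(F)F)nn1` differs from compound 1 in one respect only: propyl in place of hydrogen on a saturated chain carbon bound to an aromatic carbon. A single measured step bears on this change. Compound 2 `Cc1cc2ccccc2nc1-c1cn(-c2ccc(F)cc2)nn1` gives > 100 ug/mL in this assay, again a limit. Compound 3 `CCCCc1cc2ccccc2nc1-c1cn(-c2ccc(F)cc2)nn1`, which carries the same change at the same place of the shared core, gives 78.3 ug/mL in this assay. Among the measured compounds shown here, the step of an at least 1.2-fold lower number from compound 2 to compound 3 (0.10 log units; that floor lies within the scatter) is the only comparison to hand, and it shows no more than a shift near the edge of the usual scatter. Compound 4 is therefore expected to sit close to the limit of this assay, with an estimated value of 80 ug/mL, between 40 ug/mL and 200 ug/mL. The step that this estimate means, an at least 1.2-fold lower number from compound 1 to compound 4 (0.09 log units; that floor lies within the scatter), is expected to be small and may not stand beyond the scatter.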

Compound 4, half-maximal inhibitory concentration: > 100 ug/mL
Compound 4: only a limit was reported; the forecaster's own chance of this, stated with the estimate: 45%; at least 1.2-fold (0.09 log units) between middle value and limit.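

In this assay compound 4 gives > 100 ug/mL as a limit of the assay and not a number. Among the compounds shown here, compound 1 stands at a limit too, so no step from compound 1 to compound 4 can be read: the limit of > 100 ug/mL in this assay, at which 3 of the 4 values shown sit. The compounds shown leave open whether propyl in place of hydrogen changes the value of compound 1 at all.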